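The source may report more compounds than this note shows. Statements on the series, on what has been measured and on what is new or still open speak of the compounds shown alone.

The measured compounds:

compound 1, `CCc1cnc(N2CCC(c3coc4c(N5CCc6cc(S(C)(=O)=O)ccc65)ncnc34)CC2)nc1`, gives 154% in a functional assay on cells for agonist activity at Glucose-dependent insulinotropic receptor (Homo sapiens), read by a luciferase reporter, with a stated time of 4 h; on this read-out higher numbers stand for larger maximal responses and lower numbers for smaller maximal responses
compound 2, `CC(O)c1cnc(N2CCC(c3coc4c(N5CCc6cc(S(C)(=O)=O)ccc65)ncnc34)CC2)nc1`, gives 33%
compound 3, `CS(=O)(=O)c1ccc2c(c1)CCN2c1ncnc2c(C3CCN(c4ncc(Cl)cn4)CC3)coc12`, gives 117%

Among these three numbers compound 3 stands second highest. The nearest number belongs to compound 1 and the furthest to compound 2; the spacing is set by the steps of a number 37 percentage points lower from compound 1 to compound 3 (beyond the scatter) and a number 84 percentage points higher from compound 2 to compound 3 (beyond the scatter), both beyond the scatter.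

Compound 4, `COc1cnc(N2CCC(c3coc4c(N5CCc6cc(S(C)(=O)=O)ccc65)ncnc34)CC2)nc1`, has not yet been measured. It differs from compound 3 in one place: methoxy in place of chloro on an aromatic carbon.

All three measured steps concern the same position on the six-membered aromatic ring with two nitrogens, so all of them bear on this change. They show that the group there moves the maximal response by large amounts in either direction: a number 121 percentage points lower from compound 1 to compound 2 (beyond the scatter), a number 37 percentage points lower from compound 1 to compound 3 (beyond the scatter) and a number 84 percentage points higher from compound 2 to compound 3 (beyond the scatter). No methoxy group has been measured at this position, so the direction for compound 4 cannot be read off directly. Methoxy, like the 1-hydroxyethyl of compound 2, brings a hydrogen-bond acceptor, but, unlike it, no donor; the expectation is therefore a step of moderate size, most likely downward, in this assay, namely a number 22 percentage points lower from compound 3 to compound 4 (beyond the scatter).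

For compound 4 the estimated value in this assay is 95%, with a range from 55% to 135%.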

Compound 4, largest response reached (Emax), in percent of the reference or control that the assay uses: 186%
For compound 4 the middle estimate is 91 percentage points below the measured one; measured number above the stated range.
By their numbers in this assay, from the lowest: compound 2; then compound 3; then compound 1; then compound 4.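

In this assay, replacing chloro with methoxy at this position gives a number 69 percentage points higher from compound 3 to compound 4 (beyond the scatter), so the group that enters here with a hydrogen-bond acceptor does not lower the maximal response, as the low value of compound 2 might have suggested. Methoxy also outdoes the ethyl group, with a number 32 percentage points higher from compound 1 to compound 4 (beyond the scatter), and the gap to the 1-hydroxyethyl group is the widest seen at this position, with a number 153 percentage points higher from compound 2 to compound 4 (beyond the scatter), which places compound 4 highest of the four, beyond the scatter from each of the others. Nothing available here explains why methoxy gives the largest response in this set.

The compounds shown leave open whether the high response is specific to methoxy or extends to a longer oxygen-linked chain such as ethoxy, or to an amine at the same position. On these data alone, it also remains open whether the low response of compound 2 is tied to the hydroxy group, and a hydroxymethyl group or a carboxylic acid at this position would add further points of comparison.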